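Isopropyl to 3-fluorobenzyl on the ring amide nitrogen

The source may report more compounds than this note shows. Statements on the series, on what has been measured and on what is new or still open speak of the compounds shown alone.

Compound 1 `CS(=O)(=O)Nc1ccc2c(c1)S(=O)(=O)N=C(C1=C(O)C3CCCC3N(C3CCCC3)C1=O)N2`: "not determined" (no result reported)
Compound 2 `CC(C)N1C(=O)C(C2=NS(=O)(=O)c3cc(NS(C)(=O)=O)ccc3N2)=C(O)C2CCCC21`: > 33000 nM

In an ADME assay on Huh-7 cells (Homo sapiens) for cytotoxicity, with a stated time of 72 h (on this read-out higher numbers stand for lower toxicity in this test and lower numbers for higher toxicity in this test), compound 2 gives > 33000 nM, which is a limit of the test and not a number. Compound 1 has no result in this assay. Compound 2 therefore stands at the limit of > 33000 nM in this assay, at which 1 of the 2 values shown sits, with nothing else to compare against. Compound 3 `CS(=O)(=O)Nc1ccc2c(c1)S(=O)(=O)N=C(C1=C(O)C3CCCC3N(Cc3cccc(F)c3)C1=O)N2` differs from compound 2 by 3-fluorobenzyl in place of isopropyl on an amide-type nitrogen in a ring. Among the compounds with values here, with no measured step in the set, the step from compound 2 to compound 3 in this assay is expected to be none beyond the scatter, estimated as an at least 1.1-fold lower number from compound 2 to compound 3 (0.04 log units; that floor lies within the scatter). Compound 3 is expected at 30000 nM, within 8000 nM to 70000 nM.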

Compound 3, half-maximal cytotoxic concentration: > 33000 nM
Compound 3 ended at the assay's limit; the forecaster's own chance of this, stated with the estimate: 60%; middle value at least 1.1-fold (0.04 log units) from the limit.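

No step can be read between compound 2 and compound 3 in this assay, since both results are limits and not numbers: the limit of > 33000 nM in this assay, at which 2 of the 3 values shown sit.

From the compounds shown here alone, whether 3-fluorobenzyl in place of isopropyl on an amide-type nitrogen in a ring alters this read-out at all stays open.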